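Moving the Methyl Around the Aryl Ring

The source may report more compounds than this note shows. Statements on the series, on what has been measured and on what is new or still open speak of the compounds shown alone.

Compound 3 `Cc1cccc(N/N=C2\CCC(C)n3c2ncc(C(=O)O)c3=O)c1` gives 0.4 umol/kg in a functional assay on the whole organism for inhibition, with Rattus norvegicus as the target (on this read-out lower numbers stand for an effect already at smaller amounts and higher numbers for an effect only at larger amounts of compound), the lowest of the three numbers, though compound 2 `CC1CC/C(=N\Nc2ccc(Cl)cc2)c2ncc(C(=O)O)c(=O)n21` with 0.5 umol/kg sits within the scatter of it; compound 1 `CC1CC/C(=N\Nc2ccc(F)cc2)c2ncc(C(=O)O)c(=O)n21` with 12.2 umol/kg lies far higher. Compound 4 `Cc1ccc(N/N=C2\CCC(C)n3c2ncc(C(=O)O)c3=O)cc1` differs from compound 3 by 4-methylphenyl in place of 3-methylphenyl on an amine nitrogen. Going by the values given here, no measured step shifts a methyl around this ring. The nearest guides are a 31-fold lower number from compound 1 to compound 3 (1.48 log units; beyond the scatter) and a 1.3-fold lower number from compound 2 to compound 3 (0.10 log units; within the scatter), both exchanges of the aryl group on the amine nitrogen, and a 24-fold lower number from compound 1 to compound 2 (1.39 log units; beyond the scatter), an exchange of the substituent on that ring. Since compound 2 and compound 3 gave comparable numbers, for compound 4 a step of a 1.3-fold higher number from compound 3 to compound 4 (0.10 log units; within the scatter) is expected, within the scatter. The estimate for compound 4 is 0.5 umol/kg, between 0.15 umol/kg and 1.6 umol/kg.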

Compound 4, dose for 50% inhibition: 1.3 umol/kg
Beside the measured number, compound 4's estimate is 2.6-fold (0.41 log units) below it; measured number inside the range.
By their numbers in this assay, from the lowest: compounds 3 and 2 (each within the scatter of the next); then compound 4; then compound 1.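

In this assay the place of the methyl on the aryl ring counts, though the atoms stay the same: moving it gives a 3.3-fold higher number from compound 3 to compound 4 (0.51 log units; beyond the scatter). On an aromatic carbon, methyl in place of chloro gives a 2.6-fold higher number from compound 2 to compound 4 (0.41 log units; beyond the scatter), while methyl in place of fluoro gives a 9.4-fold lower number from compound 1 to compound 4 (0.97 log units; beyond the scatter), so this methyl falls short of chloro but not of fluoro. Nothing measured here explains these steps. The compounds shown leave open how 3-chlorophenyl or a methoxy group on the aryl ring would compare, and whether the carboxylic acid can be exchanged for an amide.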